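The source may report more compounds than this note shows. Statements on the series, on what has been measured and on what is new or still open speak of the compounds shown alone.

In an ADME assay on MRC5 cells (Homo sapiens) for cytotoxicity, read by neutral red uptake (a higher number here means that more compound is tolerated, a lower number that less compound is tolerated), three compounds have been measured, and none of them gives a number. Compound 1 `O=c1[nH]c(SCc2ccccc2[N+](=O)[O-])nc2ccccc12` reads > 64000 nM, which is a limit. Compound 2 `O=c1[nH]c(SCc2c([N+](=O)[O-])cccc2[N+](=O)[O-])nc2ccccc12` reads > 64000 nM, again a limit. Compound 3 `O=c1[nH]c(SCc2cc([N+](=O)[O-])cc([N+](=O)[O-])c2)nc2ccc(Br)cc12` reads > 64000 nM, also a limit. Together these readings amount to the limit of > 64000 nM in this assay, at which 3 of the 3 values shown sit, so compound 3 has no measured number to set it apart from the other two.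

Compound 4 `CN(C)c1ccc2nc(SCc3cc([N+](=O)[O-])cc([N+](=O)[O-])c3)[nH]c(=O)c2c1` differs from compound 3 in one place: dimethylamino in place of bromo on an aromatic carbon. This puts dimethylamino in place of bromo on an aromatic carbon. Within the data shown here, the only measured step, a step that the two limits leave unreadable from compound 1 to compound 2, is a different change, nitro in place of hydrogen on an aromatic carbon, and it offers no size to carry over. No step beyond the scatter is therefore expected in this assay, and the expectation rests on the limit of compound 3 at > 64000 nM. The expected step is an at least 1.1-fold lower number from compound 3 to compound 4 (0.06 log units; that floor lies within the scatter). For compound 4 the estimate is 55000 nM, with an expected range of 20000 nM to 64000 nM.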

Compound 4, half-maximal cytotoxic concentration: 14000 nM
Compound 4: middle estimate off by 3.9-fold (0.59 log units), on the high side; measured number outside the range, below it.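

In this assay, dimethylamino in place of bromo on this aromatic carbon gives an at least 4.5-fold lower number from compound 3 to compound 4 (0.66 log units; beyond the scatter), so this is the first change shown whose size can be read, and it lies beyond the scatter. Compound 3 carries only a limit, so the true step may be larger than this floor. Compound 4 is the only compound shown that leaves the ceiling and gives a measured number, while the others remain at their limit: the limit of > 64000 nM in this assay, at which 3 of the 4 values shown sit.

The compounds shown leave open whether a smaller amine, such as a primary amine, or a methoxy or carboxylic acid group on this carbon would lower the number in the same way. They also leave open whether dimethylamino has the same effect with other nitro patterns on the benzyl part.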